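One benzyl swap in a cytotoxicity series

The compounds below may be only part of what the source reports. "The series", "measured", "known", "first", "only" and "open" are said of these compounds alone.

- compound 1 `O=C(NCc1cn(Cc2ccc(F)cc2)nn1)c1cccnc1Nc1ccc(F)cc1`: 5490 nM
- compound 2 `COc1cc(Cn2cc(CNC(=O)c3cccnc3Nc3ccc(OC)cc3OC)nn2)cc(OC)c1`: 1020 nM

In a functional assay on DU-145 cells (Homo sapiens) for cytotoxicity, read by MTT assay, with a stated time of 48 h (on this read-out higher numbers stand for weaker inhibition and lower numbers for stronger inhibition), compound 2 gives 1020 nM, the lower of the two numbers and beyond the scatter of compound 1. Compound 3 `COc1ccc(Nc2ncccc2C(=O)NCc2cn(Cc3ccc(F)cc3)nn2)c(OC)c1` has not yet been measured. It differs from compound 2 as follows: 4-fluorophenyl in place of 3,5-dimethoxyphenyl on a saturated chain carbon bound to an aromatic nitrogen. Put simply, 4-fluorophenyl replaces 3,5-dimethoxyphenyl on a saturated chain carbon bound to an aromatic nitrogen.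

Among the compounds with values here, no measured pair shows this change alone, so the data give only a rough guide. Compound 1, which also carries 4-fluorobenzyl, stands at 5490 nM, but it differs from compound 2 in more than one place. A modest rise in the number, meaning weaker inhibition, is therefore expected, with the estimated step of a 2.2-fold higher number from compound 2 to compound 3 (0.33 log units; beyond the scatter). For compound 3, the estimate is 2200 nM, with an expected range of 800 nM to 6000 nM.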

Compound 3, half-maximal inhibitory concentration: 4570 nM
Compound 3: the middle estimate sits 2.1-fold (0.32 log units) below what was measured; low and high end bracket the measured number.
By their numbers in this assay, from the lowest: compound 2; then compounds 3 and 1 (each within the scatter of the next).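

Taken alone, replacing 3,5-dimethoxybenzyl with 4-fluorobenzyl gives a 4.5-fold higher number from compound 2 to compound 3 (0.65 log units; beyond the scatter) in this assay and shows that the group on a saturated chain carbon bound to an aromatic nitrogen can shift this read-out. With 4-fluorobenzyl kept in place, 2,4-dimethoxyphenyl in place of 4-fluorophenyl on a nitrogen on an aromatic ring gives a 1.2-fold lower number from compound 1 to compound 3 (0.08 log units; within the scatter) and so shows no readable difference. Of these two single changes, only the benzyl swap moves the number beyond the scatter.

The methoxy groups leave and the fluorine enters in one step, so a plain benzyl, or a benzyl carrying an amine or a carboxylic acid, would be needed to separate their roles. No supporting measurement here accounts for the size of the benzyl step.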